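Whole-animal minimum effective dose: from compound 2 to compound 3

This account rests on a few compounds, and the source may have more. Where it says the series, first, only, none or still open, it means among the compounds named here.

Compound 1 `CCC1(CCCCN2CCN(c3ccc(F)c(Cl)c3)CC2)C(=O)Nc2ccccc21` — in a functional assay on the whole organism (strain Wistar) with Rattus norvegicus as the target, with a stated time of 5 min (on this read-out lower numbers stand for an effect already at smaller amounts and higher numbers for an effect only at larger amounts of compound), compound 1 gives > 20 mg/kg, which is a limit of the assay and not a number.
Compound 2 `CCC1(CCCCN2CCN(c3ccccc3Cl)CC2)C(=O)Nc2ccccc21` — in this assay compound 2 gives > 20 mg/kg, again a limit of the assay rather than a number.

Among the compounds with values here, compound 2 thus stands only at a limit in this assay, and so does the one other compound measured; both sit at the limit of > 20 mg/kg in this assay, at which 2 of the 2 values shown sit. Within the data shown here, the single measured step, a step that the two limits leave unreadable from compound 1 to compound 2, is therefore unreadable in size and direction, and it concerns a different change on the same ring nitrogen.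

The next compound, compound 3 `CCC1(CCCCN2CCN(c3cccc(OC)c3)CC2)C(=O)Nc2ccccc21`, differs from compound 2 by 3-methoxyphenyl in place of 2-chlorophenyl on an amine nitrogen in a ring. Among the measured compounds shown here, no measured step bears on this change. For the measured compounds named here, with both measured compounds at the limit and the one step between them unreadable, no direction can be drawn from the data; the expected step of a number no higher from compound 2 to compound 3 (the limit leaves the size open) is an estimate without support from a measured step. The minimum effective dose of compound 3 in this assay is estimated at 20 mg/kg, with a range from 5 mg/kg to 60 mg/kg, and a limit result is considered the more likely outcome.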

Compound 3, minimum effective dose: > 20 mg/kg
Compound 3: only a limit was reported; the forecaster's own chance of this, stated with the estimate: 70%; the middle value lies on the limit itself.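

Compound 3 stays at a limit in this assay, as do compound 1 and compound 2, so no new step among these three compounds can be read: the limit of > 20 mg/kg in this assay, at which 3 of the 3 values shown sit.

The compounds shown leave open whether any group on this amine nitrogen in a ring of the shared core gives a minimum effective dose readable as a number in this assay.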